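The compounds below may be only part of what the source reports. "The series", "measured", "known", "first", "only" and "open" are said of these compounds alone.

Compound 3 `Cc1c(C)c2c(c(C)c1OC/C=C/c1ccccc1)CCC(C)(COc1ccc(/C=C3\SC(=O)NC3=O)cc1)O2` is the starting point of this step. Within the data shown here, in a functional assay on MCF7 cells (Homo sapiens), tested at 2.5 uM (a lower number here means a stronger effect, a higher number a weaker effect of the compound at the concentration tested), compound 3 gives 92%, the second highest of the three numbers measured so far; its nearest neighbour is compound 1 `CC(C)=CCOc1c(C)c(C)c2c(c1C)CCC(C)(COc1ccc(/C=C3\SC(=O)NC3=O)cc1F)O2`, which gives 95%, and its furthest is compound 2 `CC(C)=CCOc1c(C)c(C)c2c(c1C)CCC(C)(COc1ccc(/C=C3\SC(=O)NC3=O)cc1C)O2`, which gives 89%, both gaps lying within the scatter. Among the measured compounds shown here, the only step measured between two compounds that differ in one place is a number 6 percentage points lower from compound 1 to compound 2 (within the scatter), and it concerns a different place on the structure than the change considered here. Compound 4 `CC(C)=CCOc1c(C)c(C)c2c(c1C)CCC(C)(COc1ccc(/C=C3\SC(=O)NC3=O)cc1)O2` differs from compound 3 by 2-methylprop-1-en-1-yl in place of 2-phenylethenyl on a saturated chain carbon bound to an oxygen on an aromatic ring. Compound 1 and compound 2 both carry the group that enters, and the numbers they show sit within the scatter of the number for compound 3, so nothing in these data points to a step beyond the scatter. Compound 4 is therefore expected to give 92%, with a range from 82% to 99%, so that the estimated step of no change at the digits printed from compound 3 to compound 4 (within the scatter) stays within the scatter.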

Compound 4, a percentage reported as activity, at one concentration (the size of the read-out at that concentration, not a potency): 76%
Compound 4: middle estimate off by 16 percentage points, on the high side; measured number outside the range, below it.
By their numbers in this assay, from the lowest: compound 4; then compounds 2, 3 and 1 (each within the scatter of the next).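

In this assay, among these compounds, the exchange of 2-phenylethenyl for 2-methylprop-1-en-1-yl on a saturated chain carbon bound to an oxygen on an aromatic ring gives a step beyond the scatter (a number 16 percentage points lower from compound 3 to compound 4 (beyond the scatter)), so this position can shift the read-out, which the earlier compounds could not show. With 2-methylprop-1-en-1-yl held in place, the aromatic carbon also counts: hydrogen in place of methyl gives a number 13 percentage points lower from compound 2 to compound 4 (beyond the scatter) and hydrogen in place of fluoro gives a number 19 percentage points lower from compound 1 to compound 4 (beyond the scatter), both beyond the scatter. Nothing measured here accounts for these steps.

From the compounds shown here alone, whether hydrogen on the aromatic carbon gives the same step when 2-phenylethenyl is present remains open. So does the reading for a saturated butyl chain or a chain ending in an amine at the first position, or for chloro or methoxy on the aromatic carbon.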